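Compounds 1 to 3: tolerated concentration and the phenyl to methyl swap

The compounds below may be only part of what the source reports. "The series", "measured", "known", "first", "only" and "open" are said of these compounds alone.

Compound 1 `C[C@H]1O[C@@]1(C)Cc1cc(=O)n(C)c(=O)n1C` gives 89000 nM in a functional assay on MDCK cells (Canis lupus familiaris) for inhibition; a lower number here means that less compound is tolerated, a higher number that more compound is tolerated
Compound 2 `Cn1c(C[C@]2(C)CCCO2)cc(=O)n(C)c1=O` gives 1380000 nM in this assay
Compound 3 `CCCCOc1nc(CC2(c3ccccc3)CCCO2)cc(=O)n1C` gives 90000 nM in this assay

Compound 3 reads 90000 nM and so lies within the scatter of compound 1, while compound 2 gives a clearly higher number, beyond the scatter of both.

Compound 4 `CCCCOc1nc(CC2(C)CCCO2)cc(=O)n1C` keeps the structure of compound 3 except at one place: methyl in place of phenyl on a saturated ring carbon of the five-membered non-aromatic ring with 1 oxygen, next to the ring oxygen. The change is methyl in place of phenyl on a saturated ring carbon and nothing else in the structure moves.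

Within the data shown here, no two measured compounds differ in one place only, so no direct step guides this swap. Compound 2 also carries methyl on that ring and gives 1380000 nM in this assay but its core differs from that of compound 3, so only part of that gap can be carried over. A moderate upward move is therefore expected, beyond the scatter but well short of that gap. The expected size is a 2.8-fold higher number from compound 3 to compound 4 (0.44 log units; beyond the scatter) on this estimate. In this assay compound 4 is estimated at 250000 nM with an expected range of 90000 nM to 800000 nM on this read-out.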

Compound 4, half-maximal cytotoxic concentration: 1080000 nM
The estimate for compound 4 lay 4.3-fold (0.64 log units) below the measured number; the whole stated range lies below it.
By their numbers in this assay, from the lowest: compounds 1 and 3 (each within the scatter of the next); then compounds 4 and 2 (each within the scatter of the next).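

Among these compounds, this is the first direct reading at this position: in this assay, methyl in place of phenyl on a saturated ring carbon of the five-membered non-aromatic ring with 1 oxygen gives a 12-fold higher number from compound 3 to compound 4 (1.08 log units; beyond the scatter), so this one place alone can shift the tolerated concentration by a large step. The change removes one six-membered aromatic ring of carbon only and five heavy atoms net, while hydrogen-bond donor and acceptor counts and net charge stay the same, so the step comes without a change in any of those counts. Nothing on hand says why the step is this large.

A single step cannot show whether it follows the loss of the aromatic ring or the loss of heavy atoms, and an ethyl group or a cyclohexyl ring at this carbon would begin to separate the two. Also open, as far as these compounds go, is whether the same swap gives a step of similar size on a different core, such as the core of compound 2.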